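The compounds below may be only part of what the source reports. "The series", "measured", "known", "first", "only" and "open" are said of these compounds alone.

For the measured compounds named here, compound 1 `NCC(O)Cn1c(=O)n(C2OC(CO)[C@@H](O)[C@H]2O)c2nc(N)nc(O)c21` stands highest of the three numbers so far recorded in a functional assay (B cells) with Mus musculus as the target (a lower number here means that less compound is needed, a higher number that more compound is needed for the effect), giving 28 uM. Compound 2 `C=CCn1c(=O)n(C2C=CC(CO)O2)c2nc(N)nc(O)c21` gives 6 uM in this assay, and compound 3 `C=CCn1c(=O)n(C2OC(CO[Si](C)(C)C(C)(C)C)[C@@H](O)[C@H]2O)c2nc(N)nc(O)c21` gives 1 uM; both gaps to compound 1 lie beyond the scatter. Compound 4 `Nc1nc(O)c2c(n1)n(C1OC(CO)[C@@H](O)[C@H]1O)c(=O)n2CC(O)CO` differs from compound 1 at a single place: hydroxy in place of amino on a saturated chain carbon, two bonds along the chain from an oxygen on a saturated carbon. Going by the values given here, no measured pair shows this change on its own, and the measured compounds differ from one another in several places at once, so nothing here isolates its effect. With that in mind, the step of a 1.1-fold lower number from compound 1 to compound 4 (0.05 log units; within the scatter) is expected to be small, in no direction that clearly passes beyond the scatter. Compound 4 is accordingly expected to give about 25 uM in this assay, within a range from 8 uM to 80 uM.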

Compound 4, concentration for half-maximal effect: 45 uM
Beside the measured number, compound 4's estimate is 1.8-fold (0.26 log units) below it; the measured number falls inside the stated range.
By their numbers in this assay, from the lowest: compound 3; then compound 2; then compounds 1 and 4 (each within the scatter of the next).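

For the compounds shown here, compound 1 and compound 4 form the first pair here that isolates this change, and in this assay hydroxy in place of amino at this chain carbon gives a 1.6-fold higher number from compound 1 to compound 4 (0.21 log units; within the scatter). At this place, then, the 3-amino-2-hydroxypropyl and 2,3-dihydroxypropyl chains cannot be told apart in this read-out. No measurement at hand offers an explanation for this result. Going by these compounds, whether a carboxylic acid, a dimethylamino group or a longer chain at this place would separate from these two remains open. So does whether the same exchange would read alike on the core of compound 2.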